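A few compounds are considered here, and "the series" means these few. Any claim that something is new, unique, unknown or untested is made for them only; others in the source may bear on it.

Of the compounds shown here, two sharing one core have been measured so far. Compound 1 `CC(C)C/N=c1\c(O)c(O)\c1=N/Cc1ccc(C#N)cc1` gives 10200 nM in a functional assay for inhibition, with Rattus norvegicus as the target; on this read-out lower numbers stand for stronger inhibition and higher numbers for weaker inhibition. Compound 2 `Cc1cc(Br)cc(C)c1C/N=c1\c(O)c(O)\c1=N/C(C)(C)C` gives 290 nM in this assay, the lower of the two numbers, and its gap to compound 1 lies well beyond the scatter. Compound 3 `CCC(C)(C)/N=c1\c(O)c(O)\c1=N/Cc1c(C)cc(Br)cc1C` is not yet measured; it differs from compound 2 by methyl in place of hydrogen on a saturated chain carbon, two bonds along the chain from a double-bonded nitrogen, which reads as tert-butyl to 1,1-dimethylpropyl. Among the compounds with values here, nothing among the two known numbers points to a change beyond the scatter for such a small addition, so the expected step of a 1.1-fold higher number from compound 2 to compound 3 (0.04 log units; within the scatter) is close to flat. Compound 3 is therefore estimated at 320 nM, with a likely range from 120 nM to 900 nM.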

Compound 3, half-maximal inhibitory concentration: 1200 nM
Beside the measured number, compound 3's estimate is 3.8-fold (0.57 log units) below it, and the stated range ends below it.
By their numbers in this assay, from the lowest: compound 2; then compound 3; then compound 1.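

In this assay, the single added methyl gives a 4.1-fold higher number from compound 2 to compound 3 (0.62 log units; beyond the scatter) and so weakens inhibition. This shows that the position on the saturated chain responds to even one extra carbon, which compounds 1 and 2 could not show because they differ in more than one place. Nothing available explains why this number rises. Still open, from the compounds shown here alone, is how a shorter isopropyl group, a cyclopentyl ring or an amine would behave here, and whether a longer chain would weaken inhibition further.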